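From chloro to fluoro on a benzyl group

The source may hold more compounds than are shown below. What is called first, only, known or untested is meant among the compounds shown, and "the series" means these compounds.

Values in a physicochemical assay for lipophilicity, using potentiometric titration, at pH 7.4 (on this read-out higher numbers stand for higher lipophilicity and lower numbers for lower lipophilicity), for the two compounds measured so far
- compound 1 `CN(C(=O)C(Cc1ccccc1Cl)CN1CCC2(CC1)OCCc1cc(F)sc12)C1CC1` at 5.52
- compound 2 `CNC(=O)[C@@H](Cc1ccccc1F)CN1CCC2(CC1)OCCc1cc(F)sc12` at 3.5

Compound 1 stands higher of the pair at 5.52 on this scale, while compound 2 at 3.5 sits lower by a gap beyond the usual scatter. The account now turns to compound 3 `CN(C(=O)C(Cc1ccccc1F)CN1CCC2(CC1)OCCc1cc(F)sc12)C1CC1` which keeps the rest of compound 1 and changes a single substituent (fluoro in place of chloro on an aromatic carbon) with fluoro in place of chloro on an aromatic carbon, ortho to a large group, so that 2-chlorobenzyl becomes 2-fluorobenzyl. Going by the values given here, no measured pair here shows this exchange on its own, so the data offer no direct precedent for its size. The estimated move a number 0.52 log units lower from compound 1 to compound 3 (beyond the scatter) is a modest fall in this assay and is expected to exceed the scatter yet stay well short of the gap between the two measured compounds. Compound 3 is therefore estimated at 5 as the expected value, with an expected range from 4.6 to 5.4 when it is measured.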

Compound 3, distribution coefficient: 4.77
The estimate for compound 3 lay 0.23 log units above the measured number; measured number inside the range.
By their numbers in this assay, from the lowest: compound 2; then compound 3; then compound 1.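

Going by these compounds alone, with compound 1 and compound 3, the exchange of chloro for fluoro stands alone for the first time, since the two compounds measured earlier differ in more than one place and their gap could not be assigned to any single change. In this assay this exchange on an aromatic carbon, ortho to a large group, gives a number 0.75 log units lower from compound 1 to compound 3 (beyond the scatter), a modest step, which shows that turning 2-chlorobenzyl into 2-fluorobenzyl moves the read-out measurably while the rest of compound 1 stays the same. Nothing in the available data bears on what lies behind this fall.

The compounds shown do not tell how the read-out would respond to a methyl group, a methoxy group, a nitrile or plain hydrogen on this same carbon, so this single pair fixes no trend across substituents at this position. They also leave open whether the exchange of chloro for fluoro would give a step of similar size with the amide of compound 2 in place of the amide shared by compound 1 and compound 3.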